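The compounds below may be only part of what the source reports. "The series", "measured", "known", "first", "only" and "open" are said of these compounds alone.

Working notes on the series. Compound 2 `CCN(CC)S(=O)(=O)c1ccc(S(=O)(=O)N2CCC[C@@H](C(=O)N3CCN(c4nc(C(C)C)no4)CC3)C2)cc1` stands at the limit of a functional assay on MIA PaCa-2 cells (Homo sapiens) for inhibition, read by MTT assay, with a stated time of 3 days; on this read-out higher numbers stand for weaker inhibition and lower numbers for stronger inhibition: in this assay compound 2 gives only the limit > 10000 nM. Compound 1 `CC(C)NS(=O)(=O)c1ccc(S(=O)(=O)N2CCC[C@@H](C(=O)N3CCN(c4nc(C(C)C)no4)CC3)C2)cc1` sits at the same limit, giving > 10000 nM in this assay. The step that the two limits leave unreadable from compound 1 to compound 2 is therefore unreadable, and the limit of > 10000 nM in this assay, at which 2 of the 2 values shown sit, is all the measured record offers. Compound 3 `CC(C)c1noc(N2CCN(C(=O)[C@@H]3CCCN(S(=O)(=O)c4ccc(S(=O)(=O)NC5CCC5)cc4)C3)CC2)n1` differs from compound 2 by cyclobutylamino in place of diethylamino on a sulfonyl sulfur. Within the data shown here, no measured step bears on this change; both neighbours sit at the limit, so no step beyond the scatter is expected in this assay, and a limit again is the likelier outcome. Compound 3 is estimated at 20000 nM (range 5000 nM to 80000 nM), a step that the limit leaves unreadable from compound 2 to compound 3 in this assay.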

Compound 3, half-maximal inhibitory concentration: > 10000 nM
Compound 3 gave a limit, no number; the forecaster's own chance of this, stated with the estimate: 85%; the middle value is on the limit's open side.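

In this assay compound 3 gives > 10000 nM, a limit and not a number. Among these compounds, no step among compound 1, compound 2 and compound 3 can be read. The compounds shown leave open whether any group on this sulfonyl sulfur changes inhibition in this assay.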